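The compounds below may be only part of what the source reports. "The series", "measured", "known", "first", "only" and "open" are said of these compounds alone.

The series shares one core, seen in compound 1 `Cc1ccc(N2C(=O)COc3ccc(-c4cnc5ccccc5c4)cc32)cc1`. In a functional assay on HCT-116 cells (Homo sapiens) for antiproliferative activity, read by MTT assay, with a stated time of 72 h (on this read-out higher numbers stand for weaker inhibition and lower numbers for stronger inhibition), compound 1 gives only a limit, > 40000 nM. Compound 2 `O=C1COc2ccc(-c3cnc4ccccc4c3)cc2N1c1ccccc1` carries hydrogen in place of methyl on an aromatic carbon, and the step between the two reads a step that the two limits leave unreadable from compound 1 to compound 2. In this assay compound 2 also gives only a limit, > 40000 nM. Compound 3 `O=C1COc2ccc(-c3ccc(O)cc3)cc2N1` is a smaller relative of the shared core, and in this assay compound 3 gives only a limit, > 40000 nM. Compound 2 therefore stands where every measured compound stands, at the limit (the limit of > 40000 nM in this assay, at which 3 of the 3 values shown sit), with no number of its own.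

Compound 4 `O=C1COc2ccc(-c3cnc4ccccc4c3)cc2N1c1ccc(Cl)cc1` differs from compound 2 in one place: chloro in place of hydrogen on an aromatic carbon. For the measured compounds named here, no measured step involves a chloro group; the only measured step in this assay reads a step that the two limits leave unreadable from compound 1 to compound 2, so nothing bears on this change directly. With three limits and no readable step, the writer expects compound 4 to stay close to where compound 2 sits, and the estimated step is a step that the limit leaves unreadable from compound 2 to compound 4. The estimate for compound 4 is 50000 nM, within a range from 12000 nM to 200000 nM, with a strong chance that only a limit is reported again.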

Compound 4, half-maximal inhibitory concentration: 36100 nM
Compound 4: middle estimate off by 1.4-fold (0.14 log units), on the high side, and the stated range covers the measured number.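

Among the compounds shown, compound 4 alone gives a number rather than a limit in this assay: the limit of > 40000 nM in this assay, at which 3 of the 4 values shown sit. On the ring para to a large group, the change from phenyl to 4-chlorophenyl reads as an at least 1.1-fold lower number from compound 2 to compound 4 (0.04 log units; that floor lies within the scatter), and the swap of chloro in place of methyl reads as an at least 1.1-fold lower number from compound 1 to compound 4 (0.04 log units; that floor lies within the scatter). From the compounds shown here alone, both steps are floors that lie within the scatter, so the chloro compound can be placed on the scale while the other two compounds cannot, and the true size of either step remains unknown.

With a single numbered value, the compounds shown give no trend across groups at this position, and they do not show whether fluoro, methoxy, an amine or a carboxylic acid there would also give a number in this assay. For the compounds shown here, they also leave open how much the quinoline-free side of the series matters, and whether 4-chlorophenyl would give a number on a different group in place of the one that compound 4 carries on the other side of the shared core.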